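Extending the Lysine Amide Cap on a Nitroxide Precursor

A few compounds are considered here, and "the series" means these few. Any claim that something is new, unique, unknown or untested is made for them only; others in the source may bear on it.

Compound 2 `CC(C)(C)OC(=O)N[C@@H](CCCCNC(=O)COc1ccc(C2=[N+]([O-])C(C)(C)C(C)(C)N2O)cc1)C(=O)O` and compound 1 `CC1(C)N(O)C(c2ccc(OCC(=O)NCCCC[C@H](N)C(=O)O)cc2)=[N+]([O-])C1(C)C` sit together within the scatter: in a functional assay on PC-12 cells (Rattus norvegicus) for inhibition, read by MTT assay (a lower number here means that less compound is needed, a higher number that more compound is needed for the effect), compound 2 gives 97700 nM, and compound 1 gives 98800 nM, so the step of a 1.0-fold lower number from compound 1 to compound 2 (0.00 log units; within the scatter) shows that capping the amine nitrogen did nothing measurable. Compound 3 `C[C@H](NC(=O)[C@@H]1CCCN1)C(=O)N[C@@H](CCCCNC(=O)COc1ccc(C2=[N+]([O-])C(C)(C)C(C)(C)N2O)cc1)C(=O)O` carries 1-(((pyrrolidin-2-yl)carbonyl)amino)ethyl in place of tert-butoxy on a carbonyl carbon. Within the data shown here, only that one step bears on this change, and it was flat, so no movement beyond the scatter is anticipated; for compound 3 the expected step is a 1.0-fold higher number from compound 2 to compound 3 (0.01 log units; within the scatter). Compound 3 is therefore estimated to give about 100000 nM in this assay, between 40000 nM and 250000 nM.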

Compound 3, half-maximal effective concentration: 99000 nM
Compound 3: the middle estimate sits 1.0-fold (0.00 log units) above what was measured; the range from low to high includes it.
By their numbers in this assay, from the lowest: compounds 2, 1 and 3 (each within the scatter of the next).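

Replacing tert-butoxy on the carbonyl carbon with the larger 1-(((pyrrolidin-2-yl)carbonyl)amino)ethyl, which brings a five-membered ring and two defined stereocentres, gives a 1.0-fold higher number from compound 2 to compound 3 (0.01 log units; within the scatter) in this assay and so adds a second flat step at this site. Measured against the free amine, the full (1-(((pyrrolidin-2-yl)carbonyl)amino)ethyl)carbonyl cap gives a 1.0-fold higher number from compound 1 to compound 3 (0.00 log units; within the scatter) as well, so neither cap shown moves the number beyond the scatter. No evidence is available to explain this flatness.

The compounds shown leave open whether a change elsewhere, such as a methyl ester in place of the carboxylic acid or a shorter chain in place of the lysine chain, would move the number.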